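The compounds below may be only part of what the source reports. "The series", "measured", "known", "first", "only" and "open" are said of these compounds alone.

Measured compounds:

Compound 1 `COc1cc(C(=O)/C(C)=C/c2c[nH]c3ccccc23)cc([Se]C)c1OC` gives 12 nM in a functional assay on A549 cells (Homo sapiens) for antiproliferative activity, read by MTT assay, with a stated time of 48 h; a higher number here means a weaker inhibitor, a lower number a stronger inhibitor.
Compound 2 `COc1cc(C(=O)/C=C/c2cn(C)c3ccccc23)cc(N)c1OC` gives 498 nM in this assay.
Compound 3 `COc1cc(C(=O)/C(C)=C/c2cn(C)c3ccccc23)cc([Se]C)c1OC` gives 18 nM in this assay.

Compounds 1 and 3 share a core, and the two are kept apart by one change only: hydrogen in place of methyl on an aromatic nitrogen. The step this change made is a 1.5-fold lower number from compound 3 to compound 1 (0.18 log units; within the scatter). Compound 2 stands apart from both, and the difference between its core and the core of compound 3 is not broken down here. What the values show is that compound 2 sits well above the other two in this assay, its number being far higher than that of compound 3 and higher still than that of compound 1.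

Compound 4 `COc1cc(C(=O)/C=C/c2c[nH]c3ccccc23)cc(N)c1OC` has not yet been measured. It is made from compound 2 by hydrogen in place of methyl on an aromatic nitrogen. The place of this change is described in the same words as for the step from compound 3 to compound 1, so it is the same change, carried out on a different core.

Going by the values given here, since the one measured instance of this change, a 1.5-fold lower number from compound 3 to compound 1 (0.18 log units; within the scatter), stayed within the usual scatter, the expectation is that the step on the core of compound 2 will also be small. The expected step is a 1.2-fold lower number from compound 2 to compound 4 (0.10 log units; within the scatter). Compound 4 is therefore estimated at 400 nM in this assay. The range considered likely for compound 4 runs from 150 nM to 1100 nM.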

Compound 4, half-maximal inhibitory concentration: 342 nM
Estimate against measurement, compound 4: 1.2-fold (0.07 log units) above, within the range that was stated.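

Replacing the methyl on the aromatic nitrogen with hydrogen gives a 1.5-fold lower number from compound 2 to compound 4 (0.16 log units; within the scatter) in this assay, so on this core too, the swap has no effect that can be told apart from the usual spread of repeated measurements. Set side by side, the two steps match in size: the same change on two cores in this assay, a 1.5-fold lower number (0.18 log units; within the scatter) from compound 3 to compound 1 and a 1.5-fold lower number (0.16 log units; within the scatter) from compound 2 to compound 4, 1.0-fold (0.01 log units) apart, within the scatter of two such steps. This shows that, in these two pairs, the change carries from one core to the other with the same small outcome, but it does not show that this would hold on any further core, and it cannot say whether hydrogen and methyl differ slightly or not at all, only that any difference is too small to detect here.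

Only hydrogen and methyl appear on that nitrogen among the compounds shown, so it remains open what an ethyl group, a longer chain or an acetyl group there would do. Also open is what the amine of compound 2 and compound 4 and the methylselanyl group of compound 1 and compound 3 each contribute, and no pair shown differs by that swap alone.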